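The source may report more compounds than this note shows. Statements on the series, on what has been measured and on what is new or still open speak of the compounds shown alone.

Going by the values given here, in a physicochemical assay for metabolic stability, read by HPLC (on this read-out lower numbers stand for a shorter-lived compound and higher numbers for a longer-lived compound), two compounds with a shared core have numbers so far. Compound 1 (`Cc1cn([C@H]2C[C@H](N=[N+]=[N-])[C@@H](COP(=O)(O)Oc3ccc(Br)cc3)O2)c(=O)[nH]c1=O`) carries 4-bromophenyl on an oxygen and gives 7.97 h there. Compound 2 (`Cc1cn([C@H]2C[C@H](N=[N+]=[N-])[C@@H](COP(=O)(O)Oc3cccnc3)O2)c(=O)[nH]c1=O`) carries pyridin-3-yl at that place and gives 3.88 h as the lower of the two numbers. This single measured step (a 2.1-fold lower number from compound 1 to compound 2 (0.31 log units; beyond the scatter)) is modest but beyond the usual scatter. Compound 3 (`Cc1cn([C@H]2C[C@H](N=[N+]=[N-])[C@@H](COP(=O)(O)Oc3ccccc3)O2)c(=O)[nH]c1=O`) is still unmeasured, and its difference from compound 2 is phenyl in place of pyridin-3-yl on an oxygen or, in words, phenyl in place of pyridin-3-yl on an oxygen. Only the measured step bears on this change, since it swaps the same group at the same oxygen. Compound 1 also has a ring of carbon only there, so a modest rise is expected, much like that step run backwards. The expected step is a 2.2-fold higher number from compound 2 to compound 3 (0.34 log units; beyond the scatter) by this estimate. The estimated value for compound 3 is 8.5 h and the expected range runs from 4.5 h to 15 h in repeated measurements.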

Compound 3, half-life: 9.47 h
Compound 3: the middle estimate sits 1.1-fold (0.05 log units) below what was measured, within the range that was stated.
By their numbers in this assay, from the lowest: compound 2; then compounds 1 and 3 (each within the scatter of the next).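

Compound 2 and compound 3 differ only in one ring atom, since phenyl and pyridin-3-yl each have 6 heavy atoms, so this assay now gives a direct comparison of the two rings on the same oxygen: a 2.4-fold higher number from compound 2 to compound 3 (0.39 log units; beyond the scatter). Replacing bromo with hydrogen on an aromatic carbon gives a 1.2-fold higher number from compound 1 to compound 3 (0.07 log units; within the scatter), so the bromo group makes no difference beyond the scatter here. The lower number of compound 2 therefore goes with the pyridin-3-yl ring, not with the absence of bromo. No measurement here explains why this ring gives the lower number. From the compounds shown here alone, whether an amine, a methoxy group or a carboxylic acid in place of that bromo would also leave the number within the scatter remains open. So does whether a longer chain on the oxygen, in place of the ring, would shift it.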